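This account rests on a few compounds, and the source may have more. Where it says the series, first, only, none or still open, it means among the compounds named here.

Measured in a functional assay on SK-OV-3 cells (Homo sapiens) for inhibition, read by CCK-8 assay, with a stated time of 70 h; on this read-out higher numbers stand for weaker inhibition and lower numbers for stronger inhibition:
- Compound 1 `c1ccc(COc2ccc(OCCOCCOC3CCCC3)cc2)cc1` gives > 100000 nM
- Compound 2 `O=C(O)c1cccc(COc2ccc(OCCOCCNC3CCCC3)cc2)c1` gives > 100000 nM
- Compound 3 `O=C(O)c1ccccc1COc1ccc(OCCOCCNC2CCCC2)cc1` gives > 100000 nM

Compound 1 sits at the limit of > 100000 nM in this assay, at which 3 of the 3 values shown sit, and this is a limit of the assay, not a number. Compound 4 `c1ccc(COc2ccc(OCCOCCNC3CCC3)cc2)cc1` has not yet been measured. Its difference from compound 1 is cyclobutylamino in place of cyclopentyloxy on a saturated chain carbon, two bonds along the chain from an oxygen on a saturated carbon and in words it is cyclobutylamino in place of cyclopentyloxy on a saturated chain carbon, two bonds along the chain from an oxygen on a saturated carbon.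

Among the compounds with values here, the only measured step in this set is a step that the two limits leave unreadable from compound 2 to compound 3 and it offers no size to carry over. Within the data shown here, no measured step makes the exchange seen in compound 4 either, so the expectation is poorly grounded. Compound 1 at > 100000 nM has only a limit to start from. A readable result would therefore be expected to lie toward stronger inhibition, while a result at the same limit remains about as likely. The expected change is an at least 2.5-fold lower number from compound 1 to compound 4 (0.39 log units; beyond the scatter) as a cautious estimate in this assay of modest size. Compound 4 is estimated at 40000 nM with an expected range from 8000 nM to 100000 nM as its span.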

Compound 4, half-maximal inhibitory concentration: 25000 nM
The estimate for compound 4 lay 1.6-fold (0.20 log units) above the measured number; the measured number falls inside the stated range.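

In this assay, putting cyclobutylamino in place of cyclopentyloxy, on a saturated chain carbon two bonds along the chain from an oxygen on a saturated carbon, gives an at least 4.0-fold lower number from compound 1 to compound 4 (0.60 log units; beyond the scatter). Within the data shown here, this is the first step in the set with a readable direction, and it shows that a change at this position alone can bring the core of compound 1 into the measurable range, with compound 4 at 25000 nM. The true size of the step remains unknown, and the step between the two carboxylic acid compounds cannot be read, because the values on which they rest are limits, not numbers: the limit of > 100000 nM in this assay, at which 3 of the 4 values shown sit.

The exchange alters two things at once, a five-membered ring becoming a four-membered one and the oxygen linking it becoming a nitrogen, so this single pair cannot say which of the two accounts for the lower number. Cyclobutyloxy or cyclopentylamino at this position on the core of compound 1 would each make only one of these changes and so could tell the two apart.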